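Furan-2-yl amide replaces cyclohexyl amide in a quinoxaline series

A few compounds are considered here, and "the series" means these few. Any claim that something is new, unique, unknown or untested is made for them only; others in the source may bear on it.

Compound 2, `O=C(Nc1ccc2nc(Nc3ccc(Cl)c(Cl)c3)c(Nc3ccc(Cl)c(Cl)c3)nc2c1)C1CCCCC1`, carries two dichloroanilino groups on the shared core and a cyclohexylcarbonyl amino group. In a toxicity assay on HepG2 cells (Homo sapiens) for cytotoxicity, read by MTT assay, with a stated time of 24 h (on this read-out lower numbers stand for higher toxicity in this test and higher numbers for lower toxicity in this test), compound 2 has no single number; its entry reads "nd" (no result reported), so nothing is known of its behaviour in this test. Compound 1, `O=C(Nc1ccc2nc(Nc3ccc(Cl)c(Cl)c3)c(Nc3ccc(Cl)c(Cl)c3)nc2c1)c1cccc(C(F)(F)F)c1`, is its companion with a trifluoromethylphenyl amide, and in this assay compound 1 likewise stands at "nd" (no result reported). Within the data shown here, the only number in the set belongs to compound 3, `O=[N+]([O-])c1ccc2nc(Nc3cccc(C(F)(F)F)c3)c(Nc3cccc(C(F)(F)F)c3)nc2c1`, which bears a nitro group and two trifluoromethylanilino groups on the same core; in this assay compound 3 gives 5850 nM.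

The step under consideration leads to compound 4, `O=C(Nc1ccc2nc(Nc3ccc(Cl)c(Cl)c3)c(Nc3ccc(Cl)c(Cl)c3)nc2c1)c1ccco1`, and consists of furan-2-yl in place of cyclohexyl on a carbonyl carbon. Among the measured compounds shown here, with no measured pair in the set to anchor the size of such a change, and with compound 2 itself unmeasured, no direction can be read from the data. For the measured compounds named here, the expectation for compound 4 therefore rests on the one number available, that of compound 3 in this assay, and the step from compound 2 to compound 4 is expected to lie within the scatter, neither clearly more nor less toxic. Compound 4 is estimated at 6000 nM, in a range from 1500 nM to 25000 nM.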

Compound 4, half-maximal cytotoxic concentration: 14800 nM
Beside the measured number, compound 4's estimate is 2.5-fold (0.39 log units) below it, within the range that was stated.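

In this assay, among these compounds, compound 4 gives 14800 nM while compound 2 stands at "nd" (no result reported), so no step from compound 2 to compound 4 can be read. The compounds shown leave open whether furan-2-yl in place of cyclohexyl on the carbonyl carbon shifts this read-out at all. Nothing further is available that bears on this result.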